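A few compounds are considered here, and "the series" means these few. Any claim that something is new, unique, unknown or untested is made for them only; others in the source may bear on it.

Compound 1 `CCCc1nc(-c2ccc(OCCC(C)CCN3CCN(c4ccncc4)C3=O)cc2)no1`, compound 2 `CCc1nc(-c2ccc(OCCC(C)CCN3CCN(c4ccncc4)C3=O)cc2)no1` and compound 3 `CC(CCOc1ccc(-c2ccc(Cl)cc2)cc1)CCN1CCN(c2ccncc2)C1=O` were each examined in an ADME assay on cells (Homo sapiens) for cytotoxicity; on this read-out higher numbers stand for lower toxicity in this test and lower numbers for higher toxicity in this test. In this assay compound 1 reaches only the limit of > 12500 nM. In this assay compound 2 likewise gives a limit, > 25000 nM. In this assay compound 3 also returns a limit, > 25000 nM. Because the values sit at the limit of > 12500 nM in this assay, at which 1 of the 3 values shown sits, and at the limit of > 25000 nM in this assay, at which 2 of the 3 values shown sit, none of the three steps between these compounds can be read: a step that the two limits leave unreadable from compound 2 to compound 1, a step that the two limits leave unreadable from compound 1 to compound 3 and a step that the two limits leave unreadable from compound 2 to compound 3 all remain of unknown size.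

The structural change from compound 2 to compound 1 is methyl in place of hydrogen on a saturated chain carbon, two bonds along the chain from an aromatic carbon, and its step could not be sized. The cores of compound 2 and compound 3 differ by 4-chlorophenyl in place of 5-ethyl-1,2,4-oxadiazol-3-yl on an aromatic carbon.

Compound 4 `CCC(CCOc1ccc(-c2ccc(Cl)cc2)cc1)CCN1CCN(c2ccncc2)C1=O` has not yet been measured in this assay. It differs from compound 3 by methyl in place of hydrogen on a saturated chain carbon, four bonds along the chain from an amide-type nitrogen in a ring and an oxygen on an aromatic ring. This is the same kind of change as that from compound 2 to compound 1, though the place differs: there the added methyl sits two bonds along the chain from an aromatic carbon, here four bonds along the chain from an amide-type nitrogen in a ring and an oxygen on an aromatic ring. Since the earlier step from compound 2 to compound 1 left both values at a limit, the expectation for compound 4 rests on compound 3 staying at > 25000 nM and is estimated as a step that the limit leaves unreadable from compound 3 to compound 4. Compound 4 is expected to give about 30000 nM in this assay, most likely again as a limit, with a range estimated from 12500 nM to 60000 nM.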

Compound 4, half-maximal cytotoxic concentration: > 25000 nM
Compound 4: only a limit was reported; the forecaster's own chance of this, stated with the estimate: 80%; the middle value lies beyond the limit too.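

In this assay compound 4 gives only a limit, > 25000 nM. Compound 3 also stands at a limit, so no step from compound 3 to compound 4 can be read: the limit of > 25000 nM in this assay, at which 3 of the 4 values shown sit.

The compounds shown leave open whether the added methyl, or any other change among them, alters the half-maximal cytotoxic concentration at all, as every value here is a limit.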